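Swapping bromine for chlorine on the shared core

The source may report more compounds than this note shows. Statements on the series, on what has been measured and on what is new or still open speak of the compounds shown alone.

Compound 1 `Cc1ccc(C(=O)Oc2ccc(Cl)cc2C(=O)Nc2ccc(C(F)(F)F)cc2)cc1`: 6900 nM
Compound 2 `O=C(Oc1ccc(Br)cc1C(=O)Nc1ccc(C(F)(F)F)cc1)c1ccc([N+](=O)[O-])cc1`: 1250 nM
Compound 3 `Cc1ccc(C(=O)Oc2ccc(Br)cc2C(=O)Nc2ccc(C(F)(F)F)cc2)cc1`: 26800 nM

In a functional assay on HepG2 cells (Homo sapiens), read by MTT assay, with a stated time of 72 h (on this read-out lower numbers stand for stronger inhibition and higher numbers for weaker inhibition), compound 2 gives the lowest number of the three, with compound 1 next and compound 3 furthest away. Compound 4 `O=C(Oc1ccc(Cl)cc1C(=O)Nc1ccc(C(F)(F)F)cc1)c1ccc([N+](=O)[O-])cc1` differs from compound 2 by chloro in place of bromo on an aromatic carbon. Within the data shown here, one measured step bears directly on this change, in the reverse direction: a 3.9-fold higher number from compound 1 to compound 3 (0.59 log units; beyond the scatter). The other step, a 21-fold higher number from compound 2 to compound 3 (1.33 log units; beyond the scatter), concerns a different group and does not inform it. Running the halogen swap backwards, the number for compound 4 is expected to fall by a modest amount beyond the scatter, a 3.1-fold lower number from compound 2 to compound 4 (0.49 log units; beyond the scatter). Compound 4 is therefore estimated at 400 nM, within a range from 150 nM to 1200 nM.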

Compound 4, half-maximal inhibitory concentration: 1150 nM
Beside the measured number, compound 4's estimate is 2.9-fold (0.46 log units) below it, and the stated range covers the measured number.
By their numbers in this assay, from the lowest: compounds 4 and 2 (each within the scatter of the next); then compound 1; then compound 3.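

With the nitro group present, chloro in place of bromo gives a 1.1-fold lower number from compound 2 to compound 4 (0.04 log units; within the scatter), so the halogen step seen with the methyl compounds does not carry over: the same change on two cores in this assay, a 3.9-fold higher number (0.59 log units; beyond the scatter) from compound 1 to compound 3 and a 1.1-fold higher number (0.04 log units; within the scatter) from compound 4 to compound 2, 3.6-fold (0.55 log units) apart, beyond the scatter of two such steps

Nitro in place of methyl still lowers the number among the chloro compounds, with a 6.0-fold lower number from compound 1 to compound 4 (0.78 log units; beyond the scatter), but by less than among the bromo compounds: the same change on two cores in this assay, a 21-fold higher number (1.33 log units; beyond the scatter) from compound 2 to compound 3 and a 6.0-fold higher number (0.78 log units; beyond the scatter) from compound 4 to compound 1, 3.6-fold (0.55 log units) apart, beyond the scatter of two such steps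

Across these four compounds, then, the effect of each change depends on the group at the other place.

On these data alone, whether fluoro in place of the halogen, or an amine in place of nitro, would follow this pattern stays open. What lies behind the dependence also stays open.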